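The compounds below may be only part of what the source reports. "The series", "measured", "known", "first", "only" and "open" are said of these compounds alone.

Two compounds of one series have a measured number in a functional assay on HepG2 cells (Homo sapiens) for cytotoxicity, read by MTT assay, with a stated time of 24 h; a lower number here means a stronger inhibitor, a higher number a weaker inhibitor. Compound 1, `O=C1/C(=C/c2cccc(F)c2)CN(S(=O)(=O)c2ccc(Cl)cc2)C/C1=C\c1cccc(F)c1`, gives 13100 nM in this assay. Compound 2, `O=C1/C(=C/c2ccc(F)cc2)CN(S(=O)(=O)c2ccc(O[N+](=O)[O-])cc2)C/C1=C\c1ccc(F)cc1`, gives 5400 nM in this assay, the lower of the two numbers, and the gap to compound 1 lies beyond the usual scatter. Compound 3, `N#Cc1ccc(S(=O)(=O)N2C/C(=C\c3ccc(F)cc3)C(=O)/C(=C/c3ccc(F)cc3)C2)cc1`, has no number yet. It differs from compound 2 in one place: cyano in place of nitrooxy on an aromatic carbon, para to a large group. Among the measured compounds shown here, no two measured compounds differ in a single place, so the data offer no earlier step for this kind of change. The expected step is a 1.3-fold higher number from compound 2 to compound 3 (0.11 log units; within the scatter), small and probably not beyond the scatter in either direction. Compound 3 is therefore estimated to give 7000 nM in this assay, with a range from 3000 nM to 18000 nM.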

Compound 3, half-maximal inhibitory concentration: 9800 nM
Compound 3: middle estimate off by 1.4-fold (0.15 log units), on the low side, within the range that was stated.
By their numbers in this assay, from the lowest: compounds 2, 3 and 1 (each within the scatter of the next, the first and the last beyond it).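

In this assay, putting cyano in place of nitrooxy, on the aromatic carbon para to a large group, gives a 1.8-fold higher number from compound 2 to compound 3 (0.26 log units; within the scatter), so this pair cannot tell the two groups apart. For this pair, then, the nitrooxy group is not needed to keep the number in this range, even though cyano carries fewer heavy atoms and fewer hydrogen-bond acceptors. No measurement offered here explains this result.

The compounds shown do not reveal whether this position would respond to a very different group, such as an amine, a carboxylic acid or a longer chain. Going by these compounds, it also remains open whether the same exchange would read alike on the core of compound 1, where the fluorine atoms sit differently.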